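A few compounds are considered here, and "the series" means these few. Any claim that something is new, unique, unknown or untested is made for them only; others in the source may bear on it.

In a functional assay on the whole organism for inhibition, with Rattus norvegicus as the target (on this read-out lower numbers stand for an effect already at smaller amounts and higher numbers for an effect only at larger amounts of compound), compound 2 (`COc1ccc(CC(C)(Oc2ccc(C(C)C)cc2)C(=O)O)cc1`) gives > 10 mg/kg, which is a limit of the assay and not a number. Compound 1 (`COc1ccccc1CC(C)(Oc1ccc(C(C)C)cc1)C(=O)O`) gives > 10 mg/kg, which is also only a limit. The whole picture so far is the limit of > 10 mg/kg in this assay, at which 2 of the 2 values shown sit, so neither compound has a measured dose for half-maximal effect.

For the measured compounds named here, the one measured change swaps 2-methoxyphenyl for 4-methoxyphenyl, and it is a step that the two limits leave unreadable from compound 1 to compound 2. With no readable size, that step offers little guide to how far a further change at this place might move the dose.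

Compound 3 (`CC(C)c1ccc(OC(C)(Cc2ccc(Cl)c(Cl)c2)C(=O)O)cc1`) changes the same group again: 3,4-dichlorophenyl in place of 4-methoxyphenyl on a saturated chain carbon, two bonds along the chain from a carbonyl carbon and an oxygen on an aromatic ring. The 3,4-dichlorophenyl group thus replaces 4-methoxyphenyl on the same saturated chain carbon, while the rest of the molecule stays the same.

The expectation must start from compound 2, whose > 10 mg/kg is again only a limit. The expected step is a step that the limit leaves unreadable from compound 2 to compound 3, with no firm direction, and another limit is quite possible. For compound 3, the estimated dose is 12 mg/kg, with an expected range from 3 mg/kg to 30 mg/kg.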

Compound 3, dose for half-maximal effect: 5 mg/kg
Beside the measured number, compound 3's estimate is 2.4-fold (0.38 log units) above it; the measured number falls inside the stated range.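

For the compounds shown here, compound 3 is the only one of the three compounds with a measured dose and not a limit, so this saturated chain carbon is now known to carry a group that gives a readable result. In this assay, putting 3,4-dichlorophenyl in place of 4-methoxyphenyl gives an at least 2.0-fold lower number from compound 2 to compound 3 (0.30 log units; that floor lies within the scatter), and putting it in place of 2-methoxyphenyl gives an at least 2.0-fold lower number from compound 1 to compound 3 (0.30 log units; that floor lies within the scatter). Each of these steps is only a floor that rests on a limit, so the real gap between the compounds stays unknown and the change cannot yet be called a clear gain: the limit of > 10 mg/kg in this assay, at which 2 of the 3 values shown sit.

The step between the two methoxyphenyl compounds still cannot be read, so nothing can be said about how moving the methoxy group affects the dose. As far as these compounds go, it also remains open whether both chlorines are needed, and whether a plain phenyl, a 4-chlorophenyl or a 4-aminophenyl group on the same carbon would give a measured dose lower than, similar to or higher than that of compound 3.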